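Changing One Aromatic Substituent in a Channel Antagonist Series

The source may hold more compounds than are shown below. What is called first, only, known or untested is meant among the compounds shown, and "the series" means these compounds.

Compound 1 `CCCN(CCC)c1cc(C(F)(F)F)ccc1CNC(=O)C(C)c1ccc(NS(C)(=O)=O)c(F)c1`: 0.3 nM
Compound 2 `COc1ccc(CSc2cc(C(F)(F)F)ccc2CNC(=O)C(C)c2ccc(NS(C)(=O)=O)c(F)c2)cc1`: 2.3 nM

In an assay on CHO cells for antagonist activity at transient receptor potential cation channel subfamily V member 1 (Homo sapiens), read by FLIPR (a lower number here means a stronger inhibitor, a higher number a weaker inhibitor), compound 1 gives 0.3 nM, while compound 2 gives 2.3 nM, the higher of the two numbers. Within the data shown here, the one measured step, a 7.7-fold higher number from compound 1 to compound 2 (0.88 log units; beyond the scatter), shows that exchanging the group on an aromatic carbon of the shared core moves the number beyond the scatter. Compound 3 `CC(C(=O)NCc1ccc(C(F)(F)F)cc1-c1cccnc1)c1ccc(NS(C)(=O)=O)c(F)c1` again exchanges the group on an aromatic carbon: pyridin-3-yl in place of (4-methoxybenzyl)sulfanyl on an aromatic carbon. Among the measured compounds shown here, that single step is the only guide, and it says nothing about a directly attached aromatic ring, so a small shift is expected. Compound 3 is expected to give 3 nM in this assay, between 0.6 nM and 15 nM. This estimate means a 1.3-fold higher number from compound 2 to compound 3 (0.12 log units; within the scatter).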

Compound 3, inhibition constant: 59.4 nM
For compound 3 the middle estimate is 20-fold (1.30 log units) below the measured one; the measured number lies above the stated range.
By their numbers in this assay, from the lowest: compound 1; then compound 2; then compound 3.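

In this assay, this position proves far less tolerant than the first step suggested: pyridin-3-yl in place of (4-methoxybenzyl)sulfanyl gives a 26-fold higher number from compound 2 to compound 3 (1.41 log units; beyond the scatter), and pyridin-3-yl in place of dipropylamino gives a 200-fold higher number from compound 1 to compound 3 (2.30 log units; beyond the scatter). A directly attached aromatic ring therefore makes compound 3 the weakest inhibitor of the three. No measured evidence accompanies this result to explain it. The compounds shown leave open whether the ring nitrogen of pyridin-3-yl matters, which a phenyl ring here could test, and how a shorter amine such as dimethylamino would compare with dipropylamino.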